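From Bromobenzyl to Phenyl on the Piperazine Nitrogen

The compounds below may be only part of what the source reports. "The series", "measured", "known", "first", "only" and "open" are said of these compounds alone.

Compound 1 `CCCn1c(=O)[nH]c2nc(-c3ccc(S(=O)(=O)N4CCN(Cc5cccc(C)c5)CC4)cc3)[nH]c2c1=O`: 0.397 nM
Compound 2 `CCCn1c(=O)[nH]c2nc(-c3ccc(S(=O)(=O)N(C)C)cc3)[nH]c2c1=O`: 18.6 nM
Compound 3 `CCCn1c(=O)[nH]c2nc(-c3ccc(S(=O)(=O)N4CCN(Cc5cccc(Br)c5)CC4)cc3)[nH]c2c1=O`: 0.148 nM

In an assay on CHO cells for displacement of a labelled ligand from adenosine receptor A2b (Homo sapiens), read by scintillation counting, with a stated time of 75 min, in the presence of a further agent that is not named here (on this read-out higher numbers stand for weaker inhibition and lower numbers for stronger inhibition), compound 3 gives the lowest of the three numbers. For the measured compounds named here, its only single-change neighbour is compound 1, and the step of a 2.7-fold lower number from compound 1 to compound 3 (0.43 log units; beyond the scatter) is modest. Compound 2, with a small dimethyl sulfonamide, gives a far higher number than compound 3, though the two differ in more than one place.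

Compound 4 `CCCn1c(=O)[nH]c2nc(-c3ccc(S(=O)(=O)N4CCN(c5ccccc5)CC4)cc3)[nH]c2c1=O` differs from compound 3 by phenyl in place of 3-bromobenzyl on an amine nitrogen in a ring. Going by the values given here, no measured step matches this change; the one single-place step concerns only a substituent swap on the benzyl ring. Compound 4 is therefore expected to give a somewhat higher number, a 5.4-fold higher number from compound 3 to compound 4 (0.73 log units; beyond the scatter), estimated at 0.8 nM with a range of 0.2 nM to 3.5 nM.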

Compound 4, inhibition constant: 0.643 nM
Beside the measured number, compound 4's estimate is 1.2-fold (0.09 log units) above it, within the range that was stated.
By their numbers in this assay, from the lowest: compound 3; then compounds 1 and 4 (each within the scatter of the next); then compound 2.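

In this assay, phenyl on the amine nitrogen in the ring gives a 4.3-fold higher number from compound 3 to compound 4 (0.64 log units; beyond the scatter) and a 1.6-fold higher number from compound 1 to compound 4 (0.21 log units; within the scatter). Compound 4 is thus separated from the 3-bromobenzyl compound but not from the 3-methylbenzyl compound, so a number this low does not depend on a benzyl group at this position. No evidence is available to account for either step. The compounds shown leave open how an unsubstituted benzyl group or a 3-chlorobenzyl group would read at this nitrogen. They also leave open what a methoxy group on the phenyl ring of compound 4 would do.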